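This account rests on a few compounds, and the source may have more. Where it says the series, first, only, none or still open, it means among the compounds named here.

Of the compounds shown here, three of one series have been measured in a functional assay on CCRF-CEM cells (Homo sapiens) for antiproliferative activity, read by MTT assay, with a stated time of 24 h, tested at 25 uM; on this read-out lower numbers stand for a stronger effect and higher numbers for a weaker effect at the one concentration tested. Compound 1 `OCC(O)Cn1nc2c(Br)c(Br)c(Br)c(Br)c2n1` gives 89%, compound 3 `C[C@@H](O)CCn1nc2c(Br)c(Br)c(Br)c(Br)c2n1` gives 81%, and compound 2 `OC(CCn1nc2c(Br)c(Br)c(Br)c(Br)c2n1)c1ccccc1` gives 123%. Going by the values given here, the one step between compounds that differ in a single place, a number 8 percentage points lower from compound 1 to compound 3 (within the scatter), concerns the hydroxylated chain and stays within the scatter. Compound 2 stands highest of the three numbers, beyond the scatter from both compound 1 and compound 3, so on this read-out it shows the weakest effect of the set.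

Compound 4 `OC(CCn1nc2c(Br)c(Br)c(Br)c(Br)c2n1)c1cccc(Br)c1` differs from compound 2 in one place: bromo in place of hydrogen on an aromatic carbon. Among the compounds with values here, no measured step touches the aromatic ring of the chain, so the step from compound 1 to compound 3 bears on it only by showing how small a change in the side chain can be. With nothing pointing in either direction, compound 4 is expected to stay close to compound 2 in this assay, with a step of a number 8 percentage points lower from compound 2 to compound 4 (within the scatter) that is not expected to pass beyond the scatter. Compound 4 is therefore estimated at 115%, between 85% and 140%.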

Compound 4, a percentage reported as activity, at one concentration (the size of the read-out at that concentration, not a potency): 123%
Compound 4: the middle estimate sits 8 percentage points below what was measured; the range from low to high includes it.
By their numbers in this assay, from the lowest: compounds 3 and 1 (each within the scatter of the next); then compounds 2 and 4 (each within the scatter of the next).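

In this assay the step reads no change at the digits printed from compound 2 to compound 4 (within the scatter) for bromo in place of hydrogen on an aromatic carbon, meta to a large group. Going by these compounds alone, the aromatic ring of the chain, which no earlier step touched, thus has its first reading: the change from phenyl to 3-bromophenyl leaves compound 4 level with compound 2, and both remain at the weak end of the series. Nothing at hand offers an explanation for this result.

Going by these compounds, whether bromo would read the same elsewhere on that ring remains open, as does whether an amine, a carboxylic acid or a methoxy group at this place would move the number beyond the scatter. Also open, on these data alone, is whether a longer chain between the hydroxyl-bearing carbon and the core would alter the picture for these phenyl compounds.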